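The source may hold more compounds than are shown below. What is called first, only, known or untested is meant among the compounds shown, and "the series" means these compounds.

Compound 1 `CC(O)(C(=O)Nc1cccc(S(=O)(=O)c2ccccc2)c1)C(F)(F)F`: in a functional assay (Cavia porcellus) with sulfonylurea receptors; K-ATP channels (Homo sapiens) as the target (on this read-out higher numbers stand for weaker inhibition and lower numbers for stronger inhibition), compound 1 gives > 30000 nM, which is a limit of the assay rather than a number.
Compound 2 `CC(O)(C(=O)Nc1ccc(S(=O)(=O)c2cccc(O)c2)cc1)C(F)(F)F`: in this assay compound 2 gives 18000 nM.
Compound 3 `CC(O)(C(=O)Nc1ccc(C(=O)c2cccc(Cl)c2)cc1)C(F)(F)F`: in this assay compound 3 gives > 30000 nM, again a limit of the assay.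

Compound 2 is thus the only one of the three with an actual number; the other two sit at the limit of > 30000 nM in this assay, at which 2 of the 3 values shown sit. Within the data shown here, no two of the measured compounds differ in just one place, so no measured step is available to lean on. Compound 4 `CC(O)(C(=O)Nc1ccc(S(=O)(=O)c2cncnc2)cc1)C(F)(F)F` differs from compound 2 by pyrimidin-5-yl in place of 3-hydroxyphenyl on a sulfonyl sulfur. In this assay only a small shift is expected, of a size within the usual scatter, if anything toward weaker inhibition. Compound 4 is therefore estimated at 25000 nM, between 8000 nM and 60000 nM. That amounts to an expected step of a 1.4-fold higher number from compound 2 to compound 4 (0.14 log units; within the scatter).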

Compound 4, half-maximal inhibitory concentration: > 30000 nM
Compound 4 gave a limit, no number (the forecaster's own chance of this, stated with the estimate: 40%); at least 1.2-fold (0.07 log units) between middle value and limit.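

In this assay, among these compounds, putting pyrimidin-5-yl in place of 3-hydroxyphenyl on a sulfonyl sulfur gives the first step that can be read at one place: an at least 1.6-fold higher number from compound 2 to compound 4 (0.22 log units; that floor lies within the scatter). The change gives no sign of stronger inhibition at this position. That step is only a floor, because compound 4 gives a limit and not a number: the limit of > 30000 nM in this assay, at which 3 of the 4 values shown sit.

On these data alone, how large the true step is remains open, as does how much the hydroxyl of compound 2 contributes on its own. Also open, as far as these compounds go, is how a ring carrying an amine or a carboxylic acid would read at this place.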